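Swapping a propyl arm for benzyl on the aryl amine

The source may hold more compounds than are shown below. What is called first, only, known or untested is meant among the compounds shown, and "the series" means these compounds.

Compound 1 `NS(=O)(=O)Oc1ccc2c(c1)CN(C(=O)c1ccc(N3CCCCC3)cc1)CC2` carries a piperidin-1-yl group on the aromatic carbon and gives 38.3% in an assay on HEK293 cells for inhibition of Steryl-sulfatase (Homo sapiens), tested at 1 uM; on this read-out higher numbers stand for a stronger effect at the one concentration tested and lower numbers for a weaker effect. Compound 2 `CCCN(CCC)c1ccc(C(=O)N2CCc3ccc(OS(N)(=O)=O)cc3C2)cc1` replaces this with dipropylamino and gives 84.7%, and the step of a number 46.4 percentage points higher from compound 1 to compound 2 (beyond the scatter) shows how much this one exchange changed the read-out. Among the two measured compounds, compound 2 stands highest.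

Compound 3 `CCCN(Cc1ccccc1)c1ccc(C(=O)N2CCc3ccc(OS(N)(=O)=O)cc3C2)cc1` differs from compound 2 by phenyl in place of ethyl on a saturated chain carbon bound to a nitrogen on an aromatic ring. For the measured compounds named here, the only measured step, from compound 1 to compound 2, altered the group on the aromatic nitrogen itself; the present change sits one bond further out, so that step bears on it only loosely and no step in this exact place exists. A modest decrease is expected for compound 3, a step of a number 12.7 percentage points lower from compound 2 to compound 3 (beyond the scatter), because compound 2 already sits high at 84.7%. Compound 3 is therefore estimated at 72%, with a range of 45% to 92%.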

Compound 3, a percentage reported as inhibition, at one concentration (the size of the read-out at that concentration, not a potency): 94.3%
For compound 3 the middle estimate is 22.3 percentage points below the measured one, outside the stated range (above it).
By their numbers in this assay, from the lowest: compound 1; then compounds 2 and 3 (each within the scatter of the next).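

Moving from propyl to benzyl on the aromatic nitrogen adds a six-membered aromatic ring of carbon one bond further out, yet the read-out in this assay cannot be told apart from that of the dipropylamino compound (a number 9.6 percentage points higher from compound 2 to compound 3 (within the scatter)), so this arm of the amine tolerates the larger group, which the earlier pair could not show. Measured against the piperidin-1-yl group, the open-chain benzyl(propyl)amino group gives a large step (a number 56 percentage points higher from compound 1 to compound 3 (beyond the scatter)), as dipropylamino did. No evidence on the reason for these numbers is available here.

From the compounds shown here alone, whether a second benzyl in place of the remaining propyl, or a benzyl ring carrying a fluorine or a methoxy group, would hold the read-out stays open. A reading at one concentration is also no potency, so compound 2 and compound 3 may still differ in a full dose-response curve.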